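Swapping tert-Butyl for Ethyl in Two Related Compounds

The compounds below may be only part of what the source reports. "The series", "measured", "known", "first", "only" and "open" are said of these compounds alone.

Compound 1 `COc1ccc(Br)cc1Nc1cc(NC(=O)Nc2c(Cl)cccc2Cl)ncn1` gives 53% in a functional assay on HCC827 cells (Homo sapiens) for inhibition, read by MTT assay, with a stated time of 48 h, tested at 10 uM; on this read-out higher numbers stand for more inhibition at the one concentration tested (going by the name of the read-out) and lower numbers for less inhibition.
Compound 2 `CC(C)(C)c1ccc(Nc2cc(NC(=O)Nc3c(Cl)cccc3Cl)ncn2)cc1` gives 42.3% in this assay.

Compound 2 stands lowest of the two numbers; its nearest neighbour is compound 1, which lies higher by a margin beyond the usual scatter. Compound 3 `CCc1ccc(Nc2cc(NC(=O)Nc3c(Cl)cccc3Cl)ncn2)cc1` differs from compound 2 in one place: ethyl in place of tert-butyl on an aromatic carbon. No measured pair shows a matching change, so there is nothing to go by beyond the two numbers shown. A small step, or none beyond the scatter, is expected in this assay. For compound 3 a value of about 38% is estimated, between 20% and 55%. This estimate means an expected step of a number 4.3 percentage points lower from compound 2 to compound 3 (within the scatter) in this assay.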

Compound 3, a percentage reported as inhibition, at one concentration (the size of the read-out at that concentration, not a potency): 58%
Compound 3: middle estimate off by 20 percentage points, on the low side; measured number outside the range, above it.
By their numbers in this assay, from the lowest: compound 2; then compounds 1 and 3 (each within the scatter of the next).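

On the aromatic carbon para to a large group, the group carried does matter: ethyl in place of tert-butyl gives a number 15.7 percentage points higher from compound 2 to compound 3 (beyond the scatter) in this assay. Placing 4-ethylphenyl instead of 5-bromo-2-methoxyphenyl on the nitrogen gives a number 5 percentage points higher from compound 1 to compound 3 (within the scatter), so this read-out does not separate these two quite different groups. Nothing available here accounts for either step.

Only two alkyl groups are shown at this position, so it remains open how a methyl group, a longer propyl chain or an amine would read there. A single tested concentration also leaves the potency of these compounds open.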